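The source may report more compounds than this note shows. Statements on the series, on what has been measured and on what is new or still open speak of the compounds shown alone.

Compound 1, `Cc1nc(N(C)C(=O)NC(=O)c2c(F)cccc2F)sc1C(=O)N/N=C/c1ccc(F)cc1`: > 100 ug/mL
Compound 2, `Cc1nc(N(C)C(=O)NC(=O)c2c(F)cccc2F)sc1C(=O)N/N=C/c1ccccc1`: 54.3 ug/mL

Among the compounds with values here, in a functional assay on HepG2 cells (Homo sapiens) for inhibition, read by MTT assay, with a stated time of 72 h (on this read-out lower numbers stand for stronger inhibition and higher numbers for weaker inhibition), compound 2 gives 54.3 ug/mL, the only number in this pair. In this assay compound 1 gives > 100 ug/mL, which is a limit rather than a number. Compound 3, `Cc1nc(N(C)C(=O)NC(=O)c2c(F)cccc2F)sc1C(=O)N/N=C/c1ccc(Cl)cc1Cl`, differs from compound 2 in one place: 2,4-dichlorophenyl in place of phenyl on a carbon with a double bond to nitrogen. Within the data shown here, the one measured step, an at least 1.8-fold lower number from compound 1 to compound 2 (0.26 log units; that floor lies within the scatter), runs the other way, a halogen leaving the ring, and its floor lies within the scatter, with compound 1 resting at the limit of > 100 ug/mL in this assay, at which 1 of the 2 values shown sits. Bringing in the 2,4-dichlorophenyl is expected to move the number upward, by about a 1.7-fold higher number from compound 2 to compound 3 (0.22 log units; within the scatter), with a fair chance of reaching the limit again. Compound 3 is estimated at 90 ug/mL, within 40 ug/mL to 200 ug/mL.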

Compound 3, half-maximal inhibitory concentration: 70 ug/mL
Beside the measured number, compound 3's estimate is 1.3-fold (0.11 log units) above it, within the range that was stated.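

With 2,4-dichlorophenyl in place of phenyl on a carbon with a double bond to nitrogen, the step of a 1.3-fold higher number from compound 2 to compound 3 (0.11 log units; within the scatter) shows that halogens on this ring do not by themselves return the read-out to the limit. Against 4-fluorophenyl, the step of an at least 1.4-fold lower number from compound 1 to compound 3 (0.15 log units; that floor lies within the scatter) gives the same picture, with only a floor to read. Compound 1 alone remains a limit rather than a number in this assay: the limit of > 100 ug/mL in this assay, at which 1 of the 3 values shown sits.

From the compounds shown here alone, whether an amine, a carboxylic acid or a methoxy group on this ring would stand clearly apart from compound 2 and compound 3 remains open. So does the reading for a single chlorine on the ring.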